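A Fluoro-Methoxyphenyl Group Replaces the Five-Membered Ring

This account rests on a few compounds, and the source may have more. Where it says the series, first, only, none or still open, it means among the compounds named here.

Values in a functional assay on HOS-TE85 cells (Homo sapiens) for inhibition, read by CCK-8 assay, with a stated time of 72 h; a lower number here means a stronger inhibitor, a higher number a weaker inhibitor:
Compound 1 `COc1ccc(C)cc1N1C(=O)CSC1c1cccc(C(=O)NCCCCc2ccccc2)c1`: 300 nM
Compound 2 `O=C(NCCCCc1ccccc1)c1cccc(C2SCC(=O)N2c2cnccn2)c1`: > 1000 nM (a limit)
Compound 3 `CC(C)(C)c1conc1N1C(=O)CSC1c1cccc(C(=O)NCCCCc2ccccc2)c1`: > 1000 nM (a limit)

Compound 3 has no number, only the limit > 1000 nM. Compound 4 `COc1ccc(F)cc1N1C(=O)CSC1c1cccc(C(=O)NCCCCc2ccccc2)c1` changes one group: a group of 9 heavy atoms (7 carbon, 1 oxygen, 1 fluorine; one six-membered aromatic ring of carbon only) in place of a group of 9 heavy atoms (7 carbon, 1 nitrogen, 1 oxygen; one five-membered aromatic ring with 2 hetero atoms), on an amide-type nitrogen in a ring. The entering 5-fluoro-2-methoxyphenyl differs from the 2-methoxy-5-methylphenyl of compound 1 in carrying fluorine rather than methyl, a swap not tested here. The closest evidence is the loss seen an at least 3.3-fold higher number from compound 1 to compound 3 (0.52 log units; beyond the scatter). The loss seen an at least 3.3-fold higher number from compound 1 to compound 2 (0.52 log units; beyond the scatter) points the same way. A return toward compound 1 is therefore expected in this assay, with the expected step being an at least 2.5-fold lower number from compound 3 to compound 4 (0.39 log units; beyond the scatter). Compound 4 is estimated at 400 nM, within an expected range of 150 nM to 1000 nM.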

Compound 4, half-maximal inhibitory concentration: 8.8 nM
Compound 4: the middle estimate sits 45-fold (1.66 log units) above what was measured; the measured number lies below the stated range.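

In this assay, the earlier changes on the amide-type nitrogen in a ring showed only losses, whereas fluoro in place of methyl on an aromatic carbon gives a 34-fold lower number from compound 1 to compound 4 (1.53 log units; beyond the scatter), so this one swap within the phenyl group carries a large gain. Against the pyrazin-2-yl and the five-membered aromatic ring, the 5-fluoro-2-methoxyphenyl gives an at least 110-fold lower number from compound 2 to compound 4 (2.05 log units; beyond the scatter) and an at least 110-fold lower number from compound 3 to compound 4 (2.05 log units; beyond the scatter). Both of these steps are minimum sizes, resting on a limit rather than a number: the limit of > 1000 nM in this assay, at which 2 of the 4 values shown sit.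

From the compounds shown here alone, whether chloro or a nitrile in place of the fluoro would keep this gain remains open. So does the effect of an amine in place of the methoxy.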